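The source may report more compounds than this note shows. Statements on the series, on what has been measured and on what is new or still open speak of the compounds shown alone.

Series notes, an assay on COS-7 cells for inhibition of patatin-like phospholipase domain-containing protein 2 (Mus musculus), tested at 200 uM; a lower number here means less inhibition, a higher number more inhibition at the concentration tested (going by the name of the read-out). Compound 1 `CCNS(=O)(=O)c1cccc(-c2ccc(OCC)cc2)c1` gives 46% in this assay; compound 2 `CCOc1ccc(-c2cccc(S(=O)(=O)N(C)C)c2)cc1` gives 63%, the highest of the two numbers, with a number 17 percentage points higher from compound 1 to compound 2 (beyond the scatter) separating them. Compound 3 `CCOc1ccc(-c2ccccc2)cc1` differs from compound 2 in one place: hydrogen in place of dimethylsulfamoyl on an aromatic carbon. Within the data shown here, no measured step removes the group on the sulfonyl sulfur altogether; the single step exchanges only dimethylamino for ethylamino there and is modest. Loss of the whole group is expected to lower inhibition, estimated as a number 43 percentage points lower from compound 2 to compound 3 (beyond the scatter), with wide uncertainty. Compound 3 is expected to give 20%, within 0% to 50%.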

Compound 3, a percentage reported as inhibition, at one concentration (the size of the read-out at that concentration, not a potency): 35%
Beside the measured number, compound 3's estimate is 15 percentage points below it; measured number inside the range.
By their numbers in this assay, from the lowest: compound 3; then compound 1; then compound 2.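

Replacing dimethylsulfamoyl with hydrogen gives a number 28 percentage points lower from compound 2 to compound 3 (beyond the scatter) in this assay and replacing ethylsulfamoyl with hydrogen gives a number 11 percentage points lower from compound 1 to compound 3 (beyond the scatter) there, so both sulfamoyl groups on this aromatic carbon add inhibition over hydrogen. Without either group, compound 3 still gives 35% at the concentration tested, so part of the inhibition remains with the shared core. No available evidence explains the gain from either group.

Still open, on these data alone, is whether a carboxylic acid or an amine on the same aromatic carbon would match dimethylsulfamoyl. A longer chain on the sulfonyl nitrogen also remains untested in the compounds shown.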